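Exchanging the Basic Amine on the Saturated Chain of Compound 1

This account rests on a few compounds, and the source may have more. Where it says the series, first, only, none or still open, it means among the compounds named here.

Compound 1 `CCN(CC)CCCOc1cc2ncnc(Nc3nc4ccc(C(=O)Nc5c(C)cccc5Cl)cc4s3)c2cc1OC` ends its saturated chain in a diethylamino group. In a functional assay on U-937 cells (Homo sapiens) for cytotoxicity, read by WST assay, with a stated time of 72 h (a lower number here means a stronger inhibitor, a higher number a weaker inhibitor), compound 1 gives 7300 nM, the higher of the two numbers recorded. Compound 2 `CCN(CC)CCCOc1cc2ncnc(Nc3nc4ccc(C(=O)Nc5c(C)cc(C)cc5C)cc4s3)c2cc1OC` differs from compound 1 only on the amide-type nitrogen; in this assay compound 2 gives 4300 nM. For the measured compounds named here, the single measured step, a 1.7-fold lower number from compound 1 to compound 2 (0.23 log units; within the scatter), therefore concerns the amide-type nitrogen and not the saturated chain.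

Compound 3 `COc1cc2c(Nc3nc4ccc(C(=O)Nc5c(C)cccc5Cl)cc4s3)ncnc2cc1OCCCN1CCC(C)CC1` arises from compound 1 by 4-methylpiperidin-1-yl in place of diethylamino on a saturated chain carbon, three bonds along the chain from an oxygen on an aromatic ring. Going by the values given here, no measured pair alters this part of the shared core, so the step from compound 1 to compound 2 does not bear directly on the change; it shows only that a change elsewhere in the molecule stayed within the scatter. With nothing to point either way, the account expects no step beyond the scatter in this assay, in either direction. For compound 3 the expected value in this assay is 6500 nM, with a range from 2500 nM to 16000 nM. The step this implies is expected to be a 1.1-fold lower number from compound 1 to compound 3 (0.05 log units; within the scatter).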

Compound 3, half-maximal inhibitory concentration: 9200 nM
Estimate against measurement, compound 3: 1.4-fold (0.15 log units) below, and the stated range covers the measured number.
By their numbers in this assay, from the lowest: compounds 2, 1 and 3 (each within the scatter of the next, the first and the last beyond it).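

In this assay the exchange of diethylamino for 4-methylpiperidin-1-yl on the saturated chain gives a 1.3-fold higher number from compound 1 to compound 3 (0.10 log units; within the scatter) and so leaves the two amines indistinguishable in this assay. For the compounds shown here, this is the first reading at this position, since the earlier step concerned only the amide-type nitrogen. It shows that the open diethylamino group and the six-membered non-aromatic ring of 4-methylpiperidin-1-yl can stand at the end of the 3-carbon propyl chain without a step beyond the scatter, and nothing available explains this result.

One exchange cannot show how far this holds: a morpholin-4-yl group, a piperazin-1-yl group, a primary amine or a carboxylic acid at the end of the chain, or a longer chain carrying the same 4-methylpiperidin-1-yl group, could still give a step beyond the scatter. On these data alone, it also remains open whether 4-methylpiperidin-1-yl would give a similar result alongside the 2,4,6-trimethylphenyl group on the amide-type nitrogen.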